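This account rests on a few compounds, and the source may have more. Where it says the series, first, only, none or still open, it means among the compounds named here.

Measured compounds:
- compound 1, `CN(C)C(=O)c1cc2cnc(Nc3ccc(NC(=O)C4(C(=O)Nc5ccccc5F)CC4)cc3)nc2n1C1CCCC1`: in a functional assay on A549 cells (Homo sapiens) for inhibition, read by CCK-8 assay, with a stated time of 72 h, tested at 10 uM (on this read-out lower numbers stand for less inhibition of growth and higher numbers for more inhibition of growth at the one concentration tested), compound 1 gives 88.6%
- compound 2, `CN(C)C(=O)c1cc2cnc(Nc3ccc(NC(=O)C4(C(=O)Nc5ccc(O)cc5)CC4)cc3)nc2n1C1CCCC1`: in this assay compound 2 gives 94.4%
- compound 3, `COC(=O)c1ccc(NC(=O)C2(C(=O)Nc3ccc(Nc4ncc5cc(C(=O)N(C)C)n(C6CCCC6)c5n4)cc3)CC2)cc1`: in this assay compound 3 gives 92%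

Compound 1 has the lowest of the three numbers, but neither neighbour is separated from it by more than the usual scatter: the step of a number 3.4 percentage points higher from compound 1 to compound 3 (within the scatter) is small, and the step of a number 5.8 percentage points higher from compound 1 to compound 2 (within the scatter) is only a little larger, so all three compounds give essentially the same result in this assay.

Compound 4, `CN(C)C(=O)c1cc2cnc(Nc3ccc(NC(=O)C4(C(=O)Nc5cccc(C#N)c5)CC4)cc3)nc2n1C1CCCC1`, differs from compound 1 in one place: 3-cyanophenyl in place of 2-fluorophenyl on an amide-type nitrogen. The two measured steps that bear on this one, from compound 1 to compound 2 and from compound 1 to compound 3, swap the same ring on the same amide-type nitrogen for two quite different rings, and both stayed within the scatter. On that evidence the exchange for 3-cyanophenyl is expected to give a step of a number 0.4 percentage points higher from compound 1 to compound 4 (within the scatter), that is, no change beyond the scatter. Compound 4 is therefore estimated to reach 89% in this assay, most likely between 78% and 96%.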

Compound 4, percent growth inhibition at one concentration: 73.6%
Estimate against measurement, compound 4: 15.4 percentage points above; measured number outside the range, below it.
By their numbers in this assay, from the lowest: compound 4; then compounds 1, 3 and 2 (each within the scatter of the next).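

For the compounds shown here, the ring on this amide-type nitrogen tolerates less change than the earlier compounds suggested: in this assay, the exchange of 2-fluorophenyl for 3-cyanophenyl gives a number 15 percentage points lower from compound 1 to compound 4 (beyond the scatter), and the comparisons with the other two rings give a number 18.4 percentage points lower from compound 3 to compound 4 (beyond the scatter) and a number 20.8 percentage points lower from compound 2 to compound 4 (beyond the scatter). Of the four rings shown, 3-cyanophenyl alone stands apart, while 2-fluorophenyl, 4-hydroxyphenyl and 4-(methoxycarbonyl)phenyl remain within the scatter of one another. No measurement available here accounts for the separate position of this ring.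

Only one ring shown carries a nitrile, so these compounds cannot tell whether the nitrile itself goes with the lower number or whether some other feature of that ring does. Also open, on these data alone, is how this assay would read for a phenyl ring bearing an amine or a carboxylic acid, or for a longer alkyl chain on this nitrogen.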